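Replacing the benzyl group of compound 1

This account rests on a few compounds, and the source may have more. Where it says the series, first, only, none or still open, it means among the compounds named here.

Compound 1 `OC[C@@]12C[C@@H]1[C@@H](n1cnc3c(NCc4ccccc4)nc(Cl)nc31)[C@H](O)[C@@H]2O`: > 100000 nM
Compound 2 `O[C@@H]1[C@H](O)[C@@H]2C[C@@H]2[C@H]1n1cnc2c(NC(C3CCC3)C3CCC3)nc(Cl)nc21`: 16000 nM

In an ADME assay on Vero 76 cells (Chlorocebus sabaeus) for cytotoxicity, read by microscopy (a lower number here means that less compound is tolerated, a higher number that more compound is tolerated), compound 1 gives > 100000 nM, which is a limit of the assay and not a number. Compound 2 gives 16000 nM, a measured number. Compound 3 `CC(C)(O)[C@@H](Nc1nc(Cl)nc2c1ncn2[C@H]1[C@H](O)[C@H](O)[C@]2(CO)C[C@H]12)C1CC1` keeps the core of compound 1 and changes one group on a nitrogen on an aromatic ring: 1-cyclopropyl-2-hydroxy-2-methylpropyl in place of benzyl on a nitrogen on an aromatic ring. Going by the values given here, no measured pair shows this change alone, so the expectation is tentative. The estimated at least 1.4-fold lower number from compound 1 to compound 3 (0.15 log units; that floor lies within the scatter) is expected to stay within the scatter, with any shift towards lower numbers. For compound 3 the estimate is 70000 nM, with an expected range from 25000 nM to 150000 nM.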

Compound 3, half-maximal cytotoxic concentration: > 100000 nM
Compound 3: a limit, no number; the forecaster's own chance of this, stated with the estimate: 65%; middle value at least 1.4-fold (0.15 log units) from the limit.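

Compound 1 and compound 3 both sit at a limit of the assay, not at a number, so no step between them can be read: the limit of > 100000 nM in this assay, at which 2 of the 3 values shown sit.

Going by these compounds, whether 1-cyclopropyl-2-hydroxy-2-methylpropyl in place of benzyl changes how much compound the cells tolerate remains open.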